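Removing the chloro group from compound 1

The compounds below may be only part of what the source reports. "The series", "measured", "known", "first", "only" and "open" are said of these compounds alone.

Measured compounds:
compound 1 `CCN(CC)CN1C(=O)/C(=N/NC(N)=S)c2cc(Cl)ccc21` gives 44000 nM
compound 2 `CCN(CC)CN1C(=O)/C(=N/NC(=S)Nc2ccc(OC)cc2)c2ccccc21` gives 4400 nM
compound 3 `CCN(CC)CN1C(=O)/C(=N/NC(=S)Nc2ccc(C)cc2)c2cc(Cl)ccc21` gives 8600 nM

All three values come from a functional assay on HeLa cells (Homo sapiens) for inhibition, read by cell counting, with a stated time of 96 h (on this read-out higher numbers stand for weaker inhibition and lower numbers for stronger inhibition), and, of these, compound 1 has the highest number. Compound 4 `CCN(CC)CN1C(=O)/C(=N/NC(N)=S)c2ccccc21` has not yet been measured. It carries hydrogen in place of chloro on an aromatic carbon and otherwise matches compound 1.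

Among the compounds with values here, the only measured single-place step, a 5.1-fold lower number from compound 1 to compound 3 (0.71 log units; beyond the scatter), is modest but lies on an amide-type nitrogen, so it does not directly cover the chloro change. Compound 2 has no chloro group and compound 3 has one. Compound 2 (4400 nM) and compound 3 (8600 nM) lie within the scatter of each other, but they differ in more than the chloro group, so this pair cannot isolate its contribution.

Within the data shown here, with no measured step at this place, no shift beyond the scatter is expected in this assay, and the range is kept wide. The expected result is a 1.1-fold lower number from compound 1 to compound 4 (0.04 log units; within the scatter). The estimate for compound 4 is 40000 nM, with an expected range of 15000 nM to 100000 nM.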

Compound 4, half-maximal inhibitory concentration: 123000 nM
For compound 4 the middle estimate is 3.1-fold (0.49 log units) below the measured one; the measured number lies above the stated range.
By their numbers in this assay, from the lowest: compounds 2 and 3 (each within the scatter of the next); then compound 1; then compound 4.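

In this assay, within the data shown here, the chloro group on the aromatic carbon now has a contribution of its own, which the earlier compounds could not isolate: a 2.8-fold higher number from compound 1 to compound 4 (0.45 log units; beyond the scatter). With no chloro group on the core, hydrogen in place of 4-methoxyphenyl on the amide-type nitrogen gives a 28-fold higher number from compound 2 to compound 4 (1.45 log units; beyond the scatter), the largest step in the set, so the substituent on that nitrogen outweighs the chloro change in size. No measurement shown here bears on the reason for either step.

Going by these compounds, it remains open whether the chloro step holds when the amide-type nitrogen carries an aryl group, since compound 2 and compound 3 differ in more than one place. Also open, on these data alone, is how bromo or a nitrile on this aromatic carbon would compare with chloro.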